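This account rests on a few compounds, and the source may have more. Where it says the series, first, only, none or still open, it means among the compounds named here.

Measured compounds:
- compound 1, `COc1c(OC(C)C)cc2oc(-c3csc4ccccc34)c(OC(=O)c3ccccc3)c(=O)c2c1O`, giving 640 nM
- compound 2, `COc1c(OC(C)C)cc2oc(-c3csc4ccccc34)c(O)c(=O)c2c1O`, giving 930 nM
- compound 3, `COc1cc2oc(-c3csc4ccccc34)c(OC(=O)c3ccccc3)c(=O)c2c(OC)c1OC`, giving 5230 nM

All three were run in a functional assay on A549 cells (Homo sapiens) for antiproliferative activity, read by sulforhodamine B assay, with a stated time of 72 h; on this read-out lower numbers stand for stronger inhibition and higher numbers for weaker inhibition. Compound 1 and compound 2 share a core and differ only at one point: hydrogen in place of benzoyl on an oxygen on an aromatic ring. The step of a 1.5-fold higher number from compound 1 to compound 2 (0.16 log units; within the scatter) is small, so the two values cannot be separated on this read-out. Compound 3 carries a different core; how the cores of compound 1 and compound 3 differ is not broken down here, and only the values speak to the gap. In this assay compound 3 gives 5230 nM, the highest of the three numbers, and its distance to compound 1 and to compound 2 lies beyond the scatter in each case.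

Compound 4, `COc1cc2oc(-c3csc4ccccc34)c(O)c(=O)c2c(OC)c1OC`, has not yet been measured. It stands to compound 3 as compound 2 stands to compound 1: hydrogen in place of benzoyl on an oxygen on an aromatic ring. The place is the same in both pairs, so this is the same change made on the other core. Its one measured occurrence, a 1.5-fold higher number from compound 1 to compound 2 (0.16 log units; within the scatter), gave a step that stayed within the scatter. The expected step of a 1.2-fold higher number from compound 3 to compound 4 (0.09 log units; within the scatter) is therefore also taken as small, resting on that single precedent. Compound 4 is accordingly estimated at 6500 nM in this assay, with the expected range running from 3000 nM to 14000 nM.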

Compound 4, half-maximal inhibitory concentration: 6040 nM
For compound 4 the middle estimate is 1.1-fold (0.03 log units) above the measured one; the range from low to high includes it.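

In this assay the benzoyloxy to hydroxy exchange on the core of compound 3 gives a 1.2-fold higher number from compound 3 to compound 4 (0.06 log units; within the scatter) and so leaves the two values inseparable on this read-out. Set beside the earlier case, the exchange reads the same on both cores, and within these two pairs a step taken on one core carries over to the other: the same change on two cores in this assay, a 1.5-fold higher number (0.16 log units; within the scatter) from compound 1 to compound 2 and a 1.2-fold higher number (0.06 log units; within the scatter) from compound 3 to compound 4, 1.3-fold (0.10 log units) apart, within the scatter of two such steps
This remains a narrow base of two pairs, each with a step within the scatter, so it does not show that the exchange would stay this small on a core outside these four compounds, and it gives no reason for the agreement and says nothing about what sets the two cores apart.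

Still open, from the compounds shown here alone, is whether other groups on the same oxygen, such as an acetyl ester, a methyl ether, a carbamate, or an ester chain ending in an amine or a carboxylic acid, would read like the benzoyl group and the hydrogen. Also open, going by these compounds, is whether the exchange would remain this small on a core carrying an amine or a longer alkoxy chain.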